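This account rests on a few compounds, and the source may have more. Where it says the series, first, only, none or still open, it means among the compounds named here.

Working notes on the series.

Compound 1 `Oc1ccccc1-c1cc(-c2cccc(C(F)(F)F)c2)cc(-c2ccccc2O)n1` carries two 2-hydroxyphenyl groups on the shared core. In a functional assay on DU-145 cells (Homo sapiens) for inhibition (a higher number here means a weaker inhibitor, a lower number a stronger inhibitor), compound 1 gives only a limit, > 50000 nM. Compound 2 `Oc1ccccc1-c1cc(-c2ccc(C(F)(F)F)cc2)cc(-c2ccccc2O)n1` differs by 4-(trifluoromethyl)phenyl in place of 3-(trifluoromethyl)phenyl on an aromatic carbon. In this assay compound 2 likewise gives only a limit, > 50000 nM. The step that the two limits leave unreadable from compound 1 to compound 2 therefore cannot be sized, because of the limit of > 50000 nM in this assay, at which 2 of the 3 values shown sit.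

Compound 3 `Oc1ccc(-c2cc(-c3cccc(C(F)(F)F)c3)cc(-c3cccc(O)c3)n2)cc1` has a different core; the difference between the core of compound 3 and the core of compound 1 is not broken down here. In this assay, going by the values given here, compound 3 gives 11100 nM, the only number in the set.

Compound 4 `Oc1ccc(-c2cc(-c3ccc(C(F)(F)F)cc3)cc(-c3cccc(O)c3)n2)cc1` is not yet measured. It differs from compound 3 by 4-(trifluoromethyl)phenyl in place of 3-(trifluoromethyl)phenyl on an aromatic carbon. Around the place the surroundings are not identical: in compound 1 the change sits meta to two 2-hydroxyphenyl groups, in compound 3 meta to a 3-hydroxyphenyl group and meta to a 4-hydroxyphenyl group, so this is the same kind of change, not the same change.

Among the compounds with values here, since the only earlier instance of this change is unreadable, the step from compound 3 to compound 4 is expected to be small, a 1.1-fold higher number from compound 3 to compound 4 (0.03 log units; within the scatter), resting on nothing beyond compound 3 at 11100 nM. For compound 4 in this assay the estimate is 12000 nM, with a range from 4000 nM to 50000 nM.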

Compound 4, half-maximal inhibitory concentration: > 50000 nM
Compound 4 ended at the assay's limit (the forecaster's own chance of this, stated with the estimate: 30%); middle value at least 4.1-fold (0.61 log units) from the limit.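

In this assay, 4-(trifluoromethyl)phenyl in place of 3-(trifluoromethyl)phenyl on the core of compound 3 gives an at least 4.5-fold higher number from compound 3 to compound 4 (0.65 log units; beyond the scatter), so on this core the 3-(trifluoromethyl)phenyl compound is the stronger inhibitor of the pair. Compound 4 gives only a limit, > 50000 nM, so the step has a lower bound and no full size. The same change on the core of compound 1 cannot be read, which leaves a single readable instance and shows neither that the effect carries from one core to the other nor that it fails to, because neither member of that pair gives a number: the limit of > 50000 nM in this assay, at which 3 of the 4 values shown sit.

Still open, as far as these compounds go, is whether anything other than trifluoromethyl on this phenyl ring, such as a nitrile, an amine or a carboxylic acid, would keep or improve on the level of compound 3. Also open, from the compounds shown here alone, is how a hydroxyphenyl group replaced one at a time would act, as the cores of compound 1 and compound 3 differ in more than one place.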